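The source may hold more compounds than are shown below. What is called first, only, known or untested is meant among the compounds shown, and "the series" means these compounds.

Measured so far in an ADME assay on BJ cells (Homo sapiens) for cytotoxicity, with a stated time of 72 h; a lower number here means that less compound is needed, a higher number that more compound is needed for the effect:
- Compound 1 `C=C[C@@](C)(/C=C/c1ccc(OCc2ccccc2)cc1)CCC=C(C)C`: > 36600 nM (a limit)
- Compound 2 `C=C[C@@](C)(/C=C/c1ccc(Nc2ccccc2)cc1)CCC=C(C)C`: > 36600 nM (a limit)

Compound 2 gives > 36600 nM, which is a limit of this assay and not a number. Neither compound has a number here, as both sit at the limit of > 36600 nM in this assay, at which 2 of the 2 values shown sit.

Compound 3 `C=C[C@@](C)(/C=C/c1ccc(Nc2ccc(OC)cc2)cc1)CCC=C(C)C` differs from compound 2 by methoxy in place of hydrogen on an aromatic carbon, para to a large group.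

For the measured compounds named here, the only measured step is a step that the two limits leave unreadable from compound 1 to compound 2, so it gives no size to carry over. No step beyond the scatter is expected, in either direction. The estimated change is a step that the limit leaves unreadable from compound 2 to compound 3. For compound 3 the expected value is 40000 nM, with an estimated range of 20000 nM to 80000 nM.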

Compound 3, half-maximal effective concentration: > 36600 nM
Compound 3: a limit, no number; the forecaster's own chance of this, stated with the estimate: 85%; the middle value lies beyond the limit too.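

For the compounds shown here, compound 3 gives > 36600 nM, a limit and not a number, so no step from compound 1 or compound 2 to compound 3 can be read. From the compounds shown here alone, the concentration at which any of these three compounds would reach the effect in this assay stays open, and so does whether the methoxy changes it.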